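Swapping a fluorophenyl for a methylthiazole on a kinase inhibitor

The source may hold more compounds than are shown below. What is called first, only, known or untested is meant among the compounds shown, and "the series" means these compounds.

Compound 1 `CN(C)c1ccc(C(=O)Nc2cccc(NC(=O)COc3ccc4c(c3)CCC(=O)N4)c2)cc1` and compound 2 `O=C(COc1ccc2c(=O)ccoc2c1)Nc1cccc(NC(=O)c2ccc(F)cc2)c1` share the same core and were both tested in an assay on isolated protein for inhibition of Rho-associated protein kinase 1 (Homo sapiens), read by scintillation counting, radiometric assay and 33P incorporation, with a stated time of 40 min, in the presence of a further agent that is not named here; on this read-out higher numbers stand for weaker inhibition and lower numbers for stronger inhibition. For compound 1 the assay reports only a limit, > 10000 nM, and not a number. Compound 2 gives 129 nM in this assay. That is the only actual number shown, while the other value is a limit, (the limit of > 10000 nM in this assay, at which 1 of the 2 values shown sits). Compound 3 `Cc1nc(C(=O)Nc2cccc(NC(=O)COc3ccc4c(=O)ccoc4c3)c2)cs1` has not yet been measured. It differs from compound 2 in one place: 2-methyl-1,3-thiazol-4-yl in place of 4-fluorophenyl on a carbonyl carbon. Among the compounds with values here, no measured pair in this set differs at that position, so there is no direct guide to how large the step will be. The change is expected to shift the result only modestly, in either direction, and quite possibly not beyond the usual scatter. Compound 3 is estimated at 200 nM, with a range from 50 nM to 1000 nM. The expected step is a 1.6-fold higher number from compound 2 to compound 3 (0.19 log units; within the scatter).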

Compound 3, half-maximal inhibitory concentration: 473 nM
Estimate against measurement, compound 3: 2.4-fold (0.37 log units) below; low and high end bracket the measured number.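

In this assay, putting 2-methyl-1,3-thiazol-4-yl in place of 4-fluorophenyl on the carbonyl carbon gives a 3.7-fold higher number from compound 2 to compound 3 (0.56 log units; beyond the scatter), so the group at this position does affect the read-out. The change weakens inhibition, yet compound 3 still gives a real number rather than a limit, which shows that a five-membered aromatic ring with 2 hetero atoms can stand here and keep measurable inhibition. No measured property of either group bears on this step, so its cause stays unknown.

Within the data shown here, with only two groups compared at this position, the step cannot be assigned to the ring size, the hetero atoms or the methyl group. A thiazole ring without the methyl group, an unsubstituted phenyl ring or a pyridine ring would help separate these three differences.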